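Aryl amide variation at the inactive end of an assay

The compounds below may be only part of what the source reports. "The series", "measured", "known", "first", "only" and "open" are said of these compounds alone.

Compound 1 `O=C(COc1ccc2cc(/C=C3/SC(=O)NC3=O)ccc2c1)Nc1ccccn1` is one of three analogues that share a core carrying an amide-linked aryl group. In an assay on isolated protein for inhibition of histone deacetylase 8 (Homo sapiens), with a stated time of 1 h (a lower number here means a stronger inhibitor, a higher number a weaker inhibitor), compound 1 gives > 50000 nM, which is a limit of the assay rather than a number. Compound 2 `O=C(COc1ccc2cc(/C=C3/SC(=O)NC3=O)ccc2c1)Nc1cccc(Cl)c1` in this assay gives > 50000 nM, again a limit. Compound 3 `O=C(COc1ccc2cc(/C=C3/SC(=O)NC3=O)ccc2c1)Nc1ccc(Br)c(Br)c1` gives > 50000 nM, also a limit. All three therefore sit at the limit of > 50000 nM in this assay, at which 3 of the 3 values shown sit, and the steps a step that the two limits leave unreadable from compound 1 to compound 2, a step that the two limits leave unreadable from compound 1 to compound 3 and a step that the two limits leave unreadable from compound 2 to compound 3 cannot be read. Compound 4 `O=C(COc1ccc2cc(/C=C3/SC(=O)NC3=O)ccc2c1)Nc1ccc(Br)cc1` differs from compound 1 by 4-bromophenyl in place of pyridin-2-yl on an amide-type nitrogen. The measured changes placing 3-chlorophenyl or 3,4-dibromophenyl on the amide-type nitrogen left every value at the limit, so nothing readable is expected here. Compound 4 is expected to give 50000 nM, between 20000 nM and 200000 nM. The expected step is a number no higher from compound 1 to compound 4 (the limit leaves the size open), most likely again unreadable.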

Compound 4, half-maximal inhibitory concentration: 16000 nM
Compound 4: middle estimate off by 3.1-fold (0.49 log units), on the high side; measured number outside the range, below it.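

In this assay, for the compounds shown here, 4-bromophenyl on the amide-type nitrogen gives the first readable number in this set, with an at least 3.1-fold lower number from compound 1 to compound 4 (0.49 log units; beyond the scatter) as pyridin-2-yl leaves. Hydrogen in place of bromo also counts, with an at least 3.1-fold lower number from compound 3 to compound 4 (0.49 log units; beyond the scatter) on the loss of one bromo, and the change from 3-chlorophenyl gives an at least 3.1-fold lower number from compound 2 to compound 4 (0.49 log units; beyond the scatter) on the same nitrogen. Only compound 4 leaves the limit, and the others remain at it: the limit of > 50000 nM in this assay, at which 3 of the 4 values shown sit.

On these data alone, the full size of these steps stays open. Also open, as far as these compounds go, is whether 4-chlorophenyl or 4-methoxyphenyl on this nitrogen would match compound 4.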